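The source may hold more compounds than are shown below. What is called first, only, known or untested is meant among the compounds shown, and "the series" means these compounds.

Compound 1 `Cc1cc(-c2nc3cc(Cl)ccc3o2)ccc1NC(=O)CN1CCN(CCN(C)C)CC1`: 24400 nM
Compound 2 `CN(C)CCCN1CCN(CC(=O)Nc2ccc(-c3nc4cc(F)ccc4o3)cc2)CC1`: 12200 nM
Compound 3 `CN(C)CCN1CCN(CC(=O)Nc2ccc(-c3nc4cc(F)ccc4o3)cc2)CC1`: 16600 nM

These three compounds were tested in a functional assay on A549 cells (Homo sapiens) for cytotoxicity, read by MTT assay, with a stated time of 24 h; a higher number here means a weaker inhibitor, a lower number a stronger inhibitor. Compound 1 shows the highest of the three numbers, yet its gaps to compound 3 and to compound 2 both fall within the scatter, so no order among the three can be read from these numbers.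

Compound 4 `Cc1cc(-c2nc3cc(Cl)ccc3o2)ccc1NC(=O)CN1CCN(CCCN(C)C)CC1` has not yet been measured. It differs from compound 1 by (dimethylamino)methyl in place of dimethylamino on a saturated chain carbon, two bonds along the chain from an amine nitrogen in a ring. The same change is made between two measured compounds: compound 3 differs from compound 2 by (dimethylamino)methyl in place of dimethylamino on a saturated chain carbon, two bonds along the chain from an amine nitrogen in a ring, and in this assay that step is a 1.4-fold lower number from compound 3 to compound 2 (0.13 log units; within the scatter). The cores of compound 1 and compound 3 are not the same, and the difference between them is not broken down here.

For compound 4 a step of similar small size is expected, a 1.3-fold lower number from compound 1 to compound 4 (0.11 log units; within the scatter). Among the measured compounds shown here, that expectation rests on the one measured example of this change, which gives a 1.4-fold lower number from compound 3 to compound 2 (0.13 log units; within the scatter). Compound 4 is therefore estimated at 19000 nM, with an expected range from 9000 nM to 40000 nM.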

Compound 4, half-maximal inhibitory concentration: 10500 nM
Compound 4: the middle estimate sits 1.8-fold (0.26 log units) above what was measured, within the range that was stated.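

Putting (dimethylamino)methyl in place of dimethylamino on the saturated chain carbon gives, in this assay, a 2.3-fold lower number from compound 1 to compound 4 (0.37 log units; beyond the scatter), a modest step but one that clears the usual scatter. Set beside the same change on the other core, this step cannot be told apart from the earlier one: the same change on two cores in this assay, a 1.4-fold lower number (0.13 log units; within the scatter) from compound 3 to compound 2 and a 2.3-fold lower number (0.37 log units; beyond the scatter) from compound 1 to compound 4, 1.7-fold (0.23 log units) apart, within the scatter of two such steps This fits with the change carrying over from one core to the other, but it rests on only two pairs, one of which stays within the scatter on its own, so it shows neither a general rule for the series nor why the number drops.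

The compounds shown leave open whether a longer chain at this place would lower the number further, or whether diethylamino at the end of the chain would behave like dimethylamino. They also leave open how far the same change would carry onto a core with a different group in place of the chlorine or the fluorine.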